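A few compounds are considered here, and "the series" means these few. Any claim that something is new, unique, unknown or untested is made for them only; others in the source may bear on it.

Working notes on the series, read in a physicochemical assay for solubility, read by nephelometry, in phosphate buffer, at pH 7.4; on this read-out higher numbers stand for higher solubility and lower numbers for lower solubility. Compound 1 `CC(=O)N1CCCC1c1cc(C(=O)Nc2nc3c(s2)CCC3)c(C)s1` gives 7810 nM and compound 2 `Cc1sc(N2CCCC2=O)cc1C(=O)Nc1nc2c(s1)CCC2` gives 3910 nM. The gap is a 2.0-fold lower number from compound 1 to compound 2 (0.30 log units; within the scatter), so the two sit together at the top of the range. Compound 3 `Cc1sc(N2CCCCC2=O)cc1C(=O)Nc1nc2c(s1)CCC2` gives 980 nM, set apart by an 8.0-fold lower number from compound 1 to compound 3 (0.90 log units; beyond the scatter) and by a 4.0-fold lower number from compound 2 to compound 3 (0.60 log units; beyond the scatter).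

Compound 4 `Cc1sc(C2CCCN2C(=O)CCN)cc1C(=O)Nc1nc2c(s1)CCC2` keeps the core of compound 1 and differs by aminomethyl in place of hydrogen on a saturated chain carbon bound to a carbonyl carbon, which reads as acetyl to (2-aminoethyl)carbonyl. Within the data shown here, no measured step makes this change. All three replace the whole group on the aromatic carbon, so they serve only as a guide to size. Among the measured compounds shown here, on that scale, a modest step toward a higher number is expected in this assay, though the direction has no direct precedent and a step within the scatter remains possible. The estimated change is a 2.6-fold higher number from compound 1 to compound 4 (0.41 log units; beyond the scatter). For compound 4 the estimated value is 20000 nM, with an expected range of 7000 nM to 60000 nM.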

Compound 4, solubility: 980 nM
The estimate for compound 4 lay 20-fold (1.31 log units) above the measured number; measured number outside the range, below it.
By their numbers in this assay, from the lowest: compounds 3 and 4 (each within the scatter of the next); then compounds 2 and 1 (each within the scatter of the next).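

With the acetyl-bearing core of compound 1 otherwise unchanged, the change from acetyl to (2-aminoethyl)carbonyl in this assay gives an 8.0-fold lower number from compound 1 to compound 4 (0.90 log units; beyond the scatter). Unlike the earlier steps, which replaced the whole group on the aromatic carbon, this one shows that adding only aminomethyl on a saturated chain carbon bound to a carbonyl carbon moves the number beyond the scatter, and downward. No measurement at hand bears on the reason for this step.

The compounds shown leave open whether the step goes with the terminal amine or with the added chain length, which an ethyl or 2-hydroxyethyl group in place of the 2-aminoethyl could separate. From the compounds shown here alone, how a carboxylic acid, a tertiary amine or a longer aminoalkyl chain would read at this place also remains open.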